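The source may hold more compounds than are shown below. What is called first, only, known or untested is meant among the compounds shown, and "the series" means these compounds.

Of the compounds shown here, three of one shared core have been measured in a physicochemical assay for lipophilicity; on this read-out lower numbers stand for lower lipophilicity and higher numbers for higher lipophilicity. Compound 1 `CCCOC(=O)/C=C(C)/C=C/CC(C)CCCC(C)C` gives 7.28. Compound 2 `CC(/C=C/CC(C)CCCC(C)C)=C\C(=O)NC(C)C` gives 5.65. Compound 3 `CCCC(=O)/C=C(C)/C=C/CC(C)CCCC(C)C` gives 6.81. Among these three numbers compound 3 stands second highest; its nearest neighbour is compound 1 and its furthest is compound 2. The smaller of these two gaps appears as a number 0.47 log units lower from compound 1 to compound 3 (beyond the scatter), the larger appears as a number 1.16 log units higher from compound 2 to compound 3 (beyond the scatter). The third measured step, a number 1.63 log units lower from compound 1 to compound 2 (beyond the scatter), involves the same carbonyl position.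

The next compound in this line, compound 4 `CC(/C=C/CC(C)CCCC(C)C)=C\C(=O)c1ccccc1`, is not yet measured. It differs from compound 3 in one place: phenyl in place of propyl on a carbonyl carbon.

Among the compounds with values here, no measured step exchanges a propyl group for a phenyl group, so the three known steps bear on this change only loosely; they show that swapping the group on this carbonyl carbon moves the number by a modest to large amount, as seen from compound 1 to compound 3 and from compound 2 to compound 3. On that basis a modest rise, a number 0.49 log units higher from compound 3 to compound 4 (beyond the scatter), is expected for compound 4. Compound 4 is therefore estimated to reach 7.3 in this assay, within a range from 6.8 to 7.8.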

Compound 4, partition coefficient: 7.26
Compound 4: the middle estimate sits 0.04 log units above what was measured; the measured number falls inside the stated range.
By their numbers in this assay, from the lowest: compound 2; then compound 3; then compounds 4 and 1 (each within the scatter of the next).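

Phenyl is the first ring shown on this carbonyl carbon, and in this assay phenyl in place of propyl gives a number 0.45 log units higher from compound 3 to compound 4 (beyond the scatter), while phenyl in place of isopropylamino gives a large step, a number 1.61 log units higher from compound 2 to compound 4 (beyond the scatter). Phenyl in place of propoxy gives a number 0.02 log units lower from compound 1 to compound 4 (within the scatter), so on this read-out these two quite different groups cannot be told apart, even though one is an aromatic ring of carbon only and the other an open chain joined through oxygen. Nothing available explains why any of these steps has the size it has.

Phenyl differs from propyl both in being a ring and in bringing 6 heavy atoms in place of 3, so the step from propyl cannot show how much of the change belongs to each difference. A longer chain such as hexyl, or a non-aromatic ring such as cyclohexyl, on the same carbonyl carbon would be needed to pull these two differences apart.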